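A few compounds are considered here, and "the series" means these few. Any claim that something is new, unique, unknown or untested is made for them only; others in the source may bear on it.

Measured compounds:
- compound 1, `Cc1cc(O)cc(-c2nn(CC#N)cc2-c2ccnc(-c3ccc(Oc4ccccc4)cc3)c2)c1`, giving 84% in a functional assay on BT-549 cells (Homo sapiens) for cytotoxicity, read by sulforhodamine B assay, with a stated time of 48 h, tested at 100 nM; on this read-out higher numbers stand for a weaker effect at the one concentration tested and lower numbers for a stronger effect
- compound 2, `COc1cc(C)cc(-c2nn(CC#N)cc2-c2ccnc(-c3ccc(N(C)C)cc3)c2)c1`, giving 66% in this assay

Of the two numbers recorded in this assay, compound 2 holds the lower one. Its nearest neighbour is compound 1, whose value sits higher by a margin that lies beyond the usual scatter, so compound 2 shows the stronger effect of the pair at the single concentration tested. Compound 3, `Cc1cc(O)cc(-c2nn(CC#N)cc2-c2ccnc(-c3ccc(N(C)C)cc3)c2)c1`, has not yet been measured in this assay. It is derived from compound 2 by one change: hydrogen in place of methyl on an oxygen on an aromatic ring. Among the measured compounds shown here, no pair of measured compounds that differ in exactly this way is available, so the size of this step cannot be read from the data. Compound 1 carries the hydroxy group and compound 2 the methoxy group, but they also differ elsewhere, so their two values say nothing specific about this change. A small step is expected in this assay, if any, most likely not beyond the scatter, with a slight lean toward a weaker effect; the step from compound 2 to compound 3 is estimated at a number 6 percentage points higher from compound 2 to compound 3 (within the scatter). Compound 3 is therefore expected to give about 72%, within a range of 55% to 90%.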

Compound 3, a percentage reported as activity, at one concentration (the size of the read-out at that concentration, not a potency): 87%
Beside the measured number, compound 3's estimate is 15 percentage points below it; the measured number falls inside the stated range.
By their numbers in this assay, from the lowest: compound 2; then compounds 1 and 3 (each within the scatter of the next).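

In this assay the change from methyl to hydrogen on the oxygen gives a number 21 percentage points higher from compound 2 to compound 3 (beyond the scatter) and so shows that this place on the 3-methoxy-5-methylphenyl group matters: with the dimethylamino group held constant, the methoxy form has the stronger effect at the one concentration tested. Among the compounds shown here, the second step, a number 3 percentage points higher from compound 1 to compound 3 (within the scatter) with dimethylamino in place of phenoxy on an aromatic carbon, shows no change beyond the scatter while the hydroxy group is held constant, so of the two single changes now readable, only the one on the oxygen moves the read-out beyond the scatter. The data shown offer nothing that explains the size of either step.

On these data alone, it remains open whether the methoxy step keeps its size when phenoxy replaces dimethylamino, since these two compounds pairs give it only with the dimethylamino group. As far as these compounds go, it is also open how an ethoxy group, a longer ether chain or an amine in place of methoxy at this oxygen-bearing place would read, and whether any of them would go beyond the methoxy form of compound 2.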